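The source may hold more compounds than are shown below. What is called first, only, known or untested is meant among the compounds shown, and "the series" means these compounds.

Among the measured compounds shown here, in a functional assay on Ehrlich cells (Mus musculus) for cytotoxicity, read by trypan blue exclusion, with a stated time of 2 h, tested at 25 ug/mL (on this read-out lower numbers stand for a weaker effect and higher numbers for a stronger effect at the one concentration tested), compound 3 `COc1ccc(C2C(C#N)=C(N)N(c3ccc(S(N)(=O)=O)cc3)C3=C2CCCC3)cc1` gives 90%, the highest of the three numbers measured so far. Compound 1 `N#CC1=C(N)N(c2ccc(S(N)(=O)=O)cc2)C2=C(CCCC2)C1c1ccccc1` gives 10% and compound 2 `N#CC1=C(N)N(c2ccc(S(N)(=O)=O)cc2)C2=C(CCCC2)C1c1ccc(O)cc1` gives 42%. Every step among them is large: a number 80 percentage points higher from compound 1 to compound 3 (beyond the scatter), a number 32 percentage points higher from compound 1 to compound 2 (beyond the scatter) and a number 48 percentage points higher from compound 2 to compound 3 (beyond the scatter). Compound 4 `N#CC1=C(N)N(c2ccc(S(N)(=O)=O)cc2)C2=C(CCCC2)C1c1cccc([N+](=O)[O-])c1` differs from compound 3 in one place: 3-nitrophenyl in place of 4-methoxyphenyl on a saturated ring carbon. For the measured compounds named here, no measured step involves a nitro group, but the three steps show that the group on this phenyl ring moves this assay strongly, and the 4-methoxyphenyl of compound 3 gave the top number. A downward step is therefore expected for compound 4, a number 45 percentage points lower from compound 3 to compound 4 (beyond the scatter), with a wide range. Compound 4 is estimated at 45%, between 15% and 85%.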

Compound 4, a percentage reported as activity, at one concentration (the size of the read-out at that concentration, not a potency): 1%
Estimate against measurement, compound 4: 44 percentage points above; measured number outside the range, below it.
By their numbers in this assay, from the lowest: compounds 4 and 1 (each within the scatter of the next); then compound 2; then compound 3.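

In this assay, the 3-nitrophenyl group on this saturated ring carbon does not separate compound 4 from the unsubstituted phenyl ring of compound 1 (a number 9 percentage points lower from compound 1 to compound 4 (within the scatter)). It falls far short of the 4-methoxyphenyl (a number 89 percentage points lower from compound 3 to compound 4 (beyond the scatter)) and the 4-hydroxyphenyl (a number 41 percentage points lower from compound 2 to compound 4 (beyond the scatter)), so the rise seen with those two groups does not extend to this nitro-bearing ring. Nothing measured here accounts for this drop. The compounds shown leave open whether the nitro group or its place on the ring matters, since both differ from compound 3. They also leave open what an amine or a chlorine atom on this phenyl ring would give.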